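From 1-Phenylethyl to 1-(Furan-2-yl)ethyl: An Expected Step

A few compounds are considered here, and "the series" means these few. Any claim that something is new, unique, unknown or untested is made for them only; others in the source may bear on it.

Three compounds built on a shared core carry different groups on an amide-type nitrogen. Compound 1 `Cc1nc(N)sc1CCCN/C(N)=N/C(=O)NCC(C)CCc1ccccc1`, compound 2 `Cc1nc(N)sc1CCCN/C(N)=N/C(=O)N[C@@H](C)c1ccccc1` and compound 3 `CCC(NC(=O)/N=C(\N)NCCCc1sc(N)nc1C)c1ccccc1` were each tested in an assay on membranes from Sf9 cells for displacement of a labelled ligand from histamine H2 receptor (Homo sapiens), read by scintillation counting, with a stated time of 60 min; a lower number here means a stronger inhibitor, a higher number a weaker inhibitor. Compound 1 gives 63.1 nM, compound 2 gives 51.3 nM, and compound 3 gives 63.1 nM. Compound 2 thus has the lowest number of the three, yet its distances to compound 1 and to compound 3 both lie within the usual scatter of repeated measurements, so the three values cannot be told apart with confidence.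

Compound 4 `Cc1nc(N)sc1CCCN/C(N)=N/C(=O)NC(C)c1ccco1` has not yet been measured. It differs from compound 2 in one place: 1-(furan-2-yl)ethyl in place of 1-phenylethyl on an amide-type nitrogen. No exchange of this kind between two measured compounds is available, so its effect cannot be read directly from the data. The three measured groups at this position sit close together in this assay, which suggests that the position tolerates some variation, although none of those groups contains a five-membered aromatic ring with a hetero atom.

For compound 4 the expected step is a 1.7-fold higher number from compound 2 to compound 4 (0.22 log units; within the scatter), a mild weakening that may well stay within the scatter. Compound 4 is therefore estimated to give about 85 nM, with a likely range from 30 nM to 250 nM.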

Compound 4, inhibition constant: 31.6 nM
Compound 4: the middle estimate sits 2.7-fold (0.43 log units) above what was measured; low and high end bracket the measured number.
By their numbers in this assay, from the lowest: compounds 4, 2, 1 and 3 (each within the scatter of the next).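

In this assay, placing 1-(furan-2-yl)ethyl where 1-phenylethyl stood on the amide-type nitrogen gives a 1.6-fold lower number from compound 2 to compound 4 (0.21 log units; within the scatter), so a five-membered aromatic ring with 1 hetero atom is accepted here about as well as the six-membered aromatic ring of carbon only. For the compounds shown here, this goes further than the earlier compounds, which varied the group on this nitrogen but all kept a phenyl ring, and it shows that the phenyl ring itself can be exchanged without a shift beyond the scatter, even though the entering group has 1 hydrogen-bond acceptor and the leaving group has 0. No measurement shown offers a reason for this outcome.

The compounds shown leave open whether a thiophen-2-yl or pyridin-2-yl ring would also keep the number in this range, and whether a ring-bearing group with an added amine or carboxylic acid would do the same. Also open, from the compounds shown here alone, is how the two separate mirror-image forms of compound 4 compare, given that its 1-(furan-2-yl)ethyl group, unlike the 1-phenylethyl group of compound 2, has no defined stereocentre.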